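Expected half-life of compound 4 in mice

A few compounds are considered here, and "the series" means these few. Any claim that something is new, unique, unknown or untested is made for them only; others in the source may bear on it.

Compound 1 `Cc1ccc(-n2nc(C(C)(C)C)cc2NC(=O)Nc2ccc(Oc3ccnc4c3[nH]c(=O)n4C)cc2F)cn1`: 12.6 h
Compound 2 `Cc1ccc(-n2nc(C(C)(C)C)cc2NC(=O)Nc2ccc(Oc3ccnc4c3n(C)c(=O)n4C)cc2F)cc1`: 9.4 h
Compound 3 `Cn1c(=O)[nH]c2nccc(Oc3ccc(NC(=O)Nc4cc(C(C)(C)C)nn4-c4cccnc4)c4ccccc34)c21`: 0.8 h

In an in vivo ADME assay on the whole organism (strain BALB/cAnNCrl) for metabolic stability, with Mus musculus as the target, at a dose of 10 mg/kg by the oral route (a higher number here means that the compound lasts longer, a lower number that the compound disappears faster), compound 2 gives the second highest of the three numbers. Its nearest neighbour is compound 1 with 12.6 h, a gap within the usual scatter, while compound 3 at 0.8 h lies far lower, beyond the scatter. Compound 4 `Cc1ccc(-n2nc(C(C)(C)C)cc2NC(=O)Nc2ccc(Oc3ccnc4[nH]c(=O)[nH]c34)cc2F)cc1` has not yet been measured. It differs from compound 2 in one place: a group of 10 heavy atoms (6 carbon, 3 nitrogen, 1 oxygen; one five-membered aromatic ring with 2 hetero atoms, one six-membered aromatic ring with 1 hetero atom) in place of a group of 12 heavy atoms (8 carbon, 3 nitrogen, 1 oxygen; one five-membered aromatic ring with 2 hetero atoms, one six-membered aromatic ring with 1 hetero atom), on an oxygen on an aromatic ring. Within the data shown here, no step between measured compounds covers this change, so its size is uncertain; compound 1 and compound 2 sit within the scatter of each other. The step is therefore expected to be small, a 1.2-fold lower number from compound 2 to compound 4 (0.07 log units; within the scatter), most likely within the scatter and with no clear direction. Compound 4 is estimated at 8 h, within 3 h to 20 h.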

Compound 4, half-life: 5.3 h
Beside the measured number, compound 4's estimate is 1.5-fold (0.18 log units) above it; the measured number falls inside the stated range.
By their numbers in this assay, from the lowest: compound 3; then compounds 4, 2 and 1 (each within the scatter of the next, the first and the last beyond it).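

In this assay the group of 10 heavy atoms, in place of the group of 12 heavy atoms on an oxygen on an aromatic ring, gives a 1.8-fold lower number from compound 2 to compound 4 (0.25 log units; within the scatter) and so offers a direct reading of this change. The half-life therefore shows no clear response to an exchange that takes this group from 0 to 2 hydrogen-bond donors. No measurement here accounts for the step. On these data alone, whether an amine or a longer chain in this place would give a similar half-life stays open.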